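The source may report more compounds than this note shows. Statements on the series, on what has been measured and on what is new or still open speak of the compounds shown alone.

Compound 1 `COCC(=O)N(Cc1ccc(OC)c(O)c1)c1cc(OC)c(OC)c(OC)c1` gives the lowest number of the three measured compounds in a functional assay on MGC-803 cells (Homo sapiens) for inhibition, read by MTT assay, with a stated time of 48 h (on this read-out higher numbers stand for weaker inhibition and lower numbers for stronger inhibition), where compound 1 gives 79 nM. Nearest to it is compound 3 `COc1ccc(N(Cc2cc(OC)c(OC)c(OC)c2)C(=O)CCl)cc1O`, which gives 24500 nM, a gap beyond the scatter; furthest is compound 2 `COc1cc(NCc2cccc(O)c2)cc(OC)c1OC`, which gives 57600 nM. Compound 4 `C=CC(=O)N(Cc1ccc(OC)c(O)c1)c1cc(OC)c(OC)c(OC)c1` has not yet been measured. It differs from compound 1 in one place: vinyl in place of methoxymethyl on a carbonyl carbon. Going by the values given here, no step between two measured compounds isolates this change, so the expectation rests on compound 1 alone. The change is a small one, and the step of a 1.3-fold higher number from compound 1 to compound 4 (0.10 log units; within the scatter) is expected to stay within the scatter, with no clear direction. Compound 4 is therefore estimated at 100 nM in this assay, with a range from 30 nM to 400 nM.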

Compound 4, half-maximal inhibitory concentration: 62 nM
The estimate for compound 4 lay 1.6-fold (0.21 log units) above the measured number; the measured number falls inside the stated range.
By their numbers in this assay, from the lowest: compounds 4 and 1 (each within the scatter of the next); then compound 3; then compound 2.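

On a carbonyl carbon whose other neighbour is an amide-type nitrogen, vinyl in place of methoxymethyl gives a 1.3-fold lower number from compound 1 to compound 4 (0.11 log units; within the scatter) in this assay. The position thus takes either group without a change beyond the scatter, whether the group has an oxygen, as methoxymethyl does, or a double bond, as vinyl does. Nothing available explains this result.

The compounds shown leave open how ethyl, aminomethyl or a longer chain on this carbonyl carbon would read in this assay, and so whether the double bond of vinyl matters at all.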